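This account rests on a few compounds, and the source may have more. Where it says the series, first, only, none or still open, it means among the compounds named here.

Three close relatives share one core. Compound 1 is `Cc1[nH]n(C)c(=O)c1/N=N/c1c(O)cc(S(=O)(=O)O)c2ccccc12`, compound 2 is `Cc1[nH]n(C(C)(C)C)c(=O)c1/N=N/c1c(O)cc(S(=O)(=O)O)c2ccccc12`, and compound 3 is `Cc1[nH]n(-c2ccc(C(=O)O)cc2)c(=O)c1/N=N/c1c(O)cc(S(=O)(=O)O)c2ccccc12`. All three were tested in an assay on BaF3 cells with thrombopoietin receptor (Homo sapiens) as the target, read by a luciferase reporter; a lower number here means a smaller maximal response, a higher number a larger maximal response. In this assay compound 1 gives < 5%, which is a limit of the assay rather than a number. Compound 2 likewise gives only a limit, < 5%. Compound 3 too reaches only a limit, < 5%. Because (the limit of < 5% in this assay, at which 3 of the 3 values shown sit), none of the three measured steps can be read: a step that the two limits leave unreadable from compound 1 to compound 2, a step that the two limits leave unreadable from compound 1 to compound 3 and a step that the two limits leave unreadable from compound 2 to compound 3. Compound 3 therefore stands exactly where its two neighbours stand, at the limit, with no indication of where any of them would fall if a number had been obtained.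

Compound 4 is `Cc1[nH]n(-c2ccc(O)cc2)c(=O)c1/N=N/c1c(O)cc(S(=O)(=O)O)c2ccccc12`. It differs from compound 3 in one place: hydroxy in place of carboxy on an aromatic carbon. Among the compounds with values here, no measured step isolates this change; the only comparisons at hand, all unreadable, concern other groups on an aromatic nitrogen. These data give no reason to expect a step in this assay in either direction beyond the scatter, and the most probable outcome is another limit. Compound 4 is thus expected to give 3%, within 0% to 12%. The step from compound 3 to compound 4 that this estimate implies is expected to be a step that the limit leaves unreadable from compound 3 to compound 4.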

Compound 4, largest response reached (reported as efficacy), in percent of the reference or control that the assay uses: < 5%
Compound 4: only a limit was reported (the forecaster's own chance of this, stated with the estimate: 85%); the middle value does not contradict the limit.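

Compound 4 gives only a limit in this assay and so none of its steps to compound 1, compound 2 or compound 3 can be read: the limit of < 5% in this assay, at which 4 of the 4 values shown sit. Going by these compounds, how large the maximal response of each of these four compounds really is, and whether any of the groups compared on the shared core changes it, stays open.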